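This account rests on a few compounds, and the source may have more. Where it says the series, first, only, none or still open, it means among the compounds named here.

Compound 1 `CC(C)[C@@H]1CC[C@@H](C)C[C@@]12N(C)C(=O)[C@@H]1[C@H]3C(=O)NC(=O)[C@H]3ON12` and compound 2 `CC(C)[C@@H]1CC[C@@H](C)C[C@@]12N(C)C(=O)[C@@H]1[C@H]3C(=O)N(c4ccccc4)C(=O)[C@H]3ON12` share one core and differ only in what sits on an amide-type nitrogen in a ring. In a functional assay, read by spectrophotometry, with a stated time of 2 h, tested at 2.5 mg/mL (a higher number here means a stronger effect of the compound at the concentration tested, a lower number a weaker effect), compound 1 gives 70%, while compound 2 gives 58.6%. Within the data shown here, the single measured step, a number 11.4 percentage points lower from compound 1 to compound 2 (beyond the scatter), leaves compound 2 with the lower of the two numbers so far. Compound 3 `CC(C)[C@@H]1CC[C@@H](C)C[C@@]12N(C)C(=O)[C@@H]1[C@H]3C(=O)N(c4ccc(Cl)cc4)C(=O)[C@H]3ON12` takes one further step from compound 2: chloro in place of hydrogen on an aromatic carbon. Among the measured compounds shown here, no measured pair swaps a chloro for a hydrogen on an aromatic carbon, so the only known step, the arrival of the phenyl itself, does not bear directly on this change; it shows merely that this part of the molecule can be altered while most of the effect remains. The expected step of a number 2.6 percentage points lower from compound 2 to compound 3 (within the scatter) is therefore none beyond the scatter. Compound 3 is estimated at 56%, within a range from 42% to 70%.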

Compound 3, a percentage reported as activity, at one concentration (the size of the read-out at that concentration, not a potency): 60.1%
Beside the measured number, compound 3's estimate is 4.1 percentage points below it; measured number inside the range.
By their numbers in this assay, from the lowest: compounds 2, 3 and 1 (each within the scatter of the next, the first and the last beyond it).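

In this assay chloro on the aromatic ring, para to a large group, gives a number 1.5 percentage points higher from compound 2 to compound 3 (within the scatter) and so leaves the read-out indistinguishable from that of the plain phenyl. Putting 4-chlorophenyl in place of the hydrogen on the amide-type nitrogen gives a number 9.9 percentage points lower from compound 1 to compound 3 (within the scatter). The phenyl step from compound 1 to compound 2 is printed as beyond the scatter, but this contrast is thin, since compound 2 and compound 3 themselves cannot be told apart. Nothing available explains these numbers.

From the compounds shown here alone, whether a different group at this ring place, such as an amine or a carboxylic acid, would shift the read-out beyond the scatter remains open. Also open, going by these compounds, is how a longer chain on the nitrogen, in place of the aromatic ring, would compare.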